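Adding a Carboxyethyl Chain to an Indole Nitrogen

The source may report more compounds than this note shows. Statements on the series, on what has been measured and on what is new or still open speak of the compounds shown alone.

Compound 1 `O=C(c1ccn2c1CSC2c1cccnc1)c1c[nH]c2cc(-c3ccc(F)cc3)ccc12` gives 75 nM in a functional assay (Oryctolagus cuniculus) for antagonist activity at platelet-activating factor receptor (Cavia porcellus) (on this read-out lower numbers stand for stronger inhibition and higher numbers for weaker inhibition), the higher of the two numbers measured, while compound 2 `CN(C)C(=O)n1cc(C(=O)c2ccn3c2CSC3c2cccnc2)c2ccc(Cc3ccccc3)cc21`, which carries a group on the ring nitrogen but also differs elsewhere, gives 13 nM in this assay. Compound 3 `O=C(O)CCn1cc(C(=O)c2ccn3c2CSC3c2cccnc2)c2ccc(-c3ccc(F)cc3)cc21` is compound 1 with 2-carboxyethyl in place of hydrogen on an aromatic nitrogen. Going by the values given here, no single-change step is available, so the expectation rests on the shared core alone. Compound 3 is expected to move modestly toward a lower number, a step of a 1.9-fold lower number from compound 1 to compound 3 (0.27 log units; within the scatter), giving an estimated 40 nM with a range from 10 nM to 150 nM in this assay.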

Compound 3, inhibition constant: 160 nM
The estimate for compound 3 lay 4.0-fold (0.60 log units) below the measured number; the whole stated range lies below it.
By their numbers in this assay, from the lowest: compound 2; then compound 1; then compound 3.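

Putting 2-carboxyethyl in place of hydrogen on the aromatic nitrogen gives a 2.1-fold higher number from compound 1 to compound 3 (0.33 log units; beyond the scatter) in this assay, which is a modest weakening of inhibition. Going by these compounds alone, this is the first reading of a change at this position alone, since compound 2 also differs elsewhere. Inhibition is not lost when this chain replaces the hydrogen. No measurement here bears on why the number rises.

As far as these compounds go, it remains open whether a methyl group, a longer chain or the methyl ester of the acid on this nitrogen would give a similar step.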